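Triazole substituent swap and cytotoxicity on HeLa cells

This account rests on a few compounds, and the source may have more. Where it says the series, first, only, none or still open, it means among the compounds named here.

Three measured compounds open the set:
compound 1, `COc1nc2ccc(Br)cc2cc1C(c1ccccc1)n1cc(C2CC2)nn1`, with -5.84% in an ADME assay on HeLa cells (Homo sapiens) for cytotoxicity, read by sulforhodamine B assay, with a stated time of 48 h, tested at 10 uM; on this read-out higher numbers stand for more inhibition at the one concentration tested (going by the name of the read-out) and lower numbers for less inhibition;
compound 2, `COc1nc2ccc(Br)cc2cc1C(c1ccccc1)n1cc(-c2cccc(F)c2)nn1`, with 9.04%;
compound 3, `CCCCCCCCc1cn(C(c2ccccc2)c2cc3cc(Br)ccc3nc2OC)nn1`, with 0.1%.

Compound 2 gives the highest of the three numbers, yet only its step to compound 1 stands apart: a number 14.9 percentage points higher from compound 1 to compound 2 (beyond the scatter), whereas a number 8.9 percentage points lower from compound 2 to compound 3 (within the scatter) and a number 5.9 percentage points higher from compound 1 to compound 3 (within the scatter) stay inside the scatter. The unmeasured compound 4, `COc1nc2ccc(Br)cc2cc1C(c1ccccc1)n1cc(CO)nn1`, is reached from compound 2 by one change: hydroxymethyl in place of 3-fluorophenyl on an aromatic carbon. The step from compound 1 to compound 2 is the one that bears on this, since it shows what the 3-fluorophenyl adds over a small group at the same position; the step from compound 2 to compound 3 shows that another large group brings no change beyond the scatter. A small hydroxymethyl therefore points back toward the level of compound 1, so for compound 4 a drop of about the size of a number 12 percentage points lower from compound 2 to compound 4 (beyond the scatter) is expected. Compound 4 is estimated at -3%, within -16% to 10%.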

Compound 4, a percentage reported as inhibition, at one concentration (the size of the read-out at that concentration, not a potency): 0.25%
The estimate for compound 4 lay 3.3 percentage points below the measured number, within the range that was stated.
By their numbers in this assay, from the lowest: compounds 1, 3, 4 and 2 (each within the scatter of the next, the first and the last beyond it).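

In this assay, within the data shown here, hydroxymethyl, the only group here with a hydrogen-bond donor and acceptor, gives a number 8.8 percentage points lower from compound 2 to compound 4 (within the scatter) and a number 6.1 percentage points higher from compound 1 to compound 4 (within the scatter) and also a number 0.2 percentage points higher from compound 3 to compound 4 (within the scatter) and so stands apart from none of the other three groups on this aromatic carbon. Among these compounds, a small group is therefore not enough to separate a compound from compound 2, and the only step beyond the scatter remains a number 14.9 percentage points higher from compound 1 to compound 2 (beyond the scatter) with cyclopropyl rather than small size alone at its lower end. No supporting measurement bears on why these numbers fall as they do.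

As far as these compounds go, whether an amine or a carboxylic acid on this carbon would give a step beyond the scatter stays open. So does whether plain phenyl, without the fluorine, would stay within the scatter of compound 2.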